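Dropping the Pyrrolidinyl Chain from Two Related Inhibitors

The source may hold more compounds than are shown below. What is called first, only, known or untested is meant among the compounds shown, and "the series" means these compounds.

Compound 1 `COc1cc2c(NCC3CCC(C(=O)NO)CC3)cc(-c3ccc(C)o3)nc2cc1OCCCN1CCCC1` was tested in an assay on isolated protein for inhibition of protein deacetylase HDAC6 (Homo sapiens), read by fluorescence, with a stated time of 30 min (a higher number here means a weaker inhibitor, a lower number a stronger inhibitor), where compound 1 gives 34 nM. Compound 2 `COc1cc2c(NCC3CCN(Cc4ccc(C(=O)NO)cc4)CC3)cc(-c3ccc(C)o3)nc2cc1OCCCN1CCCC1` shares much of its framework with compound 1, but the difference between the two cores is not broken down here. In this assay compound 2 gives 53 nM. Compound 3 `COc1cc2nc(-c3ccc(C)o3)cc(NCC3CCC(C(=O)NO)CC3)c2cc1OC` differs from compound 1 by a single change, (hydrogen in place of 2-(pyrrolidin-1-yl)ethyl on a saturated chain carbon bound to an oxygen on an aromatic ring), and in this assay compound 3 gives 41 nM. That change made a step of a 1.2-fold higher number from compound 1 to compound 3 (0.08 log units; within the scatter), so the two numbers sit within the usual scatter of one another.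

Compound 4 `COc1cc2nc(-c3ccc(C)o3)cc(NCC3CCN(Cc4ccc(C(=O)NO)cc4)CC3)c2cc1OC` has not yet been measured. It arises from compound 2 by hydrogen in place of 2-(pyrrolidin-1-yl)ethyl on a saturated chain carbon bound to an oxygen on an aromatic ring, the same change that turns compound 1 into compound 3, at a place described in identical words. Because the earlier step was a 1.2-fold higher number from compound 1 to compound 3 (0.08 log units; within the scatter), the step from compound 2 to compound 4 is expected to be about a 1.2-fold higher number from compound 2 to compound 4 (0.08 log units; within the scatter). Compound 4 is therefore estimated at 64 nM in this assay, with a likely range from 30 nM to 135 nM.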

Compound 4, half-maximal inhibitory concentration: 84 nM
The estimate for compound 4 lay 1.3-fold (0.12 log units) below the measured number, within the range that was stated.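

In this assay, trading the 3-(pyrrolidin-1-yl)propoxy group for methoxy on the second core gave a 1.6-fold higher number from compound 2 to compound 4 (0.20 log units; within the scatter), so on this core too the change stays small enough to be lost in the ordinary noise of the measurement. The two steps also agree with each other as far as these numbers can tell: the same change on two cores in this assay, a 1.2-fold higher number (0.08 log units; within the scatter) from compound 1 to compound 3 and a 1.6-fold higher number (0.20 log units; within the scatter) from compound 2 to compound 4, 1.3-fold (0.12 log units) apart, within the scatter of two such steps. Among the compounds shown here, this supports carrying the change between these two cores in this assay, but two cores are only one pair, and steps this small cannot show whether the chain has a modest effect on binding strength or none at all.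

As far as these compounds go, what remains open is whether other groups in place of the 3-(pyrrolidin-1-yl)propyl group, such as a chain ending in a morpholine ring or a carboxylic acid, would give an equally small step. From the compounds shown here alone, it is also open whether the same change stays this small on a third core.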